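Piperidin-1-ylmethyl for carbamoyl on the saturated chain

The source may report more compounds than this note shows. Statements on the series, on what has been measured and on what is new or still open speak of the compounds shown alone.

Measured so far in an assay for inhibition of RAC-alpha serine/threonine-protein kinase (Homo sapiens), read by HTRF, with a stated time of 1 h; on this read-out higher numbers stand for weaker inhibition and lower numbers for stronger inhibition:
Compound 1 `Cn1ncc(Cl)c1-c1cc(C(=O)N[C@H]2CNCC[C@@H]2c2ccc(C(F)(F)F)cc2)oc1Cl` gives 127 nM.
Compound 2 `CC(=O)NCC[C@@H]1C[C@@H](c2ccc(F)c(F)c2)[C@H](NC(=O)c2cc(-c3c(Cl)cnn3C)c(Cl)o2)CN1` gives 2.49 nM.
Compound 3 `Cn1ncc(Cl)c1-c1cc(C(=O)N[C@@H]2CN[C@H](CC(N)=O)C[C@H]2c2ccc(Cl)c(Cl)c2)oc1Cl` gives 3.24 nM.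

Compound 3 and compound 2 give numbers that lie within the usual scatter of each other, so nothing separates them on this read-out. Compound 1, by contrast, gives a number far higher than that of compound 3, a gap well beyond the scatter. Compound 3 thus stands in the stronger pair of the three, with compound 1 on its own at the weaker end.

Compound 4 `Cn1ncc(Cl)c1-c1cc(C(=O)N[C@@H]2CN[C@H](CCN3CCCCC3)C[C@H]2c2ccc(Cl)c(Cl)c2)oc1Cl` is not yet measured. It differs from compound 3 in one place: (piperidin-1-yl)methyl in place of carbamoyl on a saturated chain carbon bound to a saturated ring carbon. The shared core, the amide and the dichlorophenyl group are unchanged. Among the compounds with values here, no measured pair shows this exact exchange, so the expectation rests on the three numbers alone. Compound 3 and compound 2 carry different groups on the same chain and still agree within the scatter, which suggests the chain substituent tolerates variation. The expected step from compound 3 to compound 4 is a 1.5-fold higher number from compound 3 to compound 4 (0.19 log units; within the scatter), small and near the scatter. Compound 4 is expected to give about 5 nM, in the range 1.5 nM to 20 nM.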

Compound 4, half-maximal inhibitory concentration: 5.65 nM
Compound 4: the middle estimate sits 1.1-fold (0.05 log units) below what was measured; the range from low to high includes it.
By their numbers in this assay, from the lowest: compounds 2, 3 and 4 (each within the scatter of the next, the first and the last beyond it); then compound 1.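

In this assay, within the data shown here, the exchange of carbamoyl for (piperidin-1-yl)methyl on a saturated chain carbon bound to a saturated ring carbon gives a 1.7-fold higher number from compound 3 to compound 4 (0.24 log units; within the scatter) and is the first single-place comparison available. It shows that this place can carry a group with a six-membered non-aromatic ring and no hydrogen-bond donor in place of carbamoyl, with no separation between the two compounds on this read-out. No measurement at hand accounts for this tolerance.

The compounds shown leave open how a carboxylic acid, a dimethylamino group or a longer chain would read at this same place. They also leave open whether a morpholine in place of the piperidine, which would put a second hetero atom in the ring, would stay as close to compound 3.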